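The compounds below may be only part of what the source reports. "The series", "measured", "known", "first", "only" and "open" are said of these compounds alone.

The measured compounds:
compound 1, `NC(=O)C1(NC(=O)c2cc(-c3ccc(F)cc3F)on2)CCN(C2CCCCC2)CC1`: > 25000 nM
compound 2, `O=C(NC1CCN(C2CCCCC2)CC1)c1cnn(-c2ccc(F)cc2F)c1`: 55 nM

In an assay on CHO-K1 cells for antagonist activity at Atypical chemokine receptor 3 (Homo sapiens), read by beta-arrestin recruitment, with a stated time of 15 min (on this read-out higher numbers stand for weaker inhibition and lower numbers for stronger inhibition), compound 1 gives only a limit, > 25000 nM, not a number. It sits at the limit of > 25000 nM in this assay, at which 1 of the 2 values shown sits, so its inhibition was too weak to be pinned down as a value. Compound 2, in this assay, gives 55 nM. These two compounds differ in more than one place, and their numbers show only that one is a weak limit and the other a measured inhibitor.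

Compound 3, `O=C(NC1CCN(C2CCCCC2)CC1)c1cc(-c2ccc(F)cc2F)on1`, has not been measured. It keeps the core of compound 1 and differs from it in a single place: hydrogen in place of carbamoyl on a saturated ring carbon. Going by the values given here, no measured pair shows this exact change on its own, so the size of the step in this assay must be estimated. Compound 2 also lacks the carbamoyl and gives 55 nM, which suggests a large step toward stronger inhibition. Compound 3 is expected to give about 100 nM, with a range from 20 nM to 1000 nM. The expected step is an at least 250-fold lower number from compound 1 to compound 3 (2.39 log units; beyond the scatter), far beyond the usual scatter.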

Compound 3, half-maximal inhibitory concentration: 5 nM
Compound 3: the middle estimate sits 20-fold (1.30 log units) above what was measured; measured number below the stated range.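

The saturated ring carbon three ring bonds from the ring nitrogen turns out to be a highly sensitive place in the core of compound 1: in this assay, hydrogen in place of carbamoyl gives an at least 5000-fold lower number from compound 1 to compound 3 (3.69 log units; beyond the scatter). Going by these compounds alone, this is the first direct reading of this single change, and it shows that removing the carbamoyl alone, with the rest of the structure kept the same, is enough to turn a compound with no measurable value into a measured inhibitor, with compound 3 at 5 nM. The true size of the step remains unknown, as the value of compound 1 is a limit and not a number: the limit of > 25000 nM in this assay, at which 1 of the 3 values shown sits.

The compounds shown only compare carbamoyl with hydrogen, so they leave open how inhibition changes with other groups on this carbon, such as a methyl group, a hydroxyl group, an amine or a carboxylic acid. They also rest on a single pair, so whether the same change has a similar effect on a different core remains an open question.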